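One More Chain Carbon Before the Terminal Group

This account rests on a few compounds, and the source may have more. Where it says the series, first, only, none or still open, it means among the compounds named here.

Three measured compounds share one core and differ in the chain that carries the terminal group. Compound 1 `CN(C)C(=O)c1cc2cnc(Nc3ccc(S(=O)(=O)NCCCCCCN=C=S)cc3)nc2n1C1CCCC1` and compound 2 `CN(C)C(=O)c1cc2cnc(Nc3ccc(S(=O)(=O)NCCCCCCCN=C=S)cc3)nc2n1C1CCCC1` attach that chain through a sulfonamide nitrogen, while compound 3 `CN(C)C(=O)c1cc2cnc(Nc3ccc(NC(=O)CCCN=C=S)cc3)nc2n1C1CCCC1` attaches it through a carbonyl. The difference between the core of compound 3 and the core of compound 1 is not broken down here.

In a functional assay on A549 cells (Homo sapiens) for inhibition, read by CCK-8 assay, with a stated time of 72 h, tested at 10 uM (a higher number here means a stronger effect of the compound at the concentration tested, a lower number a weaker effect), compound 1 gives 101%. Compound 2 differs from compound 1 by a group of 4 heavy atoms (2 carbon, 1 nitrogen, 1 sulfur; no ring) in place of a group of 3 heavy atoms (1 carbon, 1 nitrogen, 1 sulfur; no ring), on a saturated chain carbon, six bonds along the chain from a sulfonamide nitrogen. In this assay compound 2 gives 101%, and the step of no change at the digits printed from compound 1 to compound 2 (within the scatter). Compound 3 gives 102% in this assay, so all three numbers lie within the scatter of one another and none can be called stronger than another.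

Compound 4 `CN(C)C(=O)c1cc2cnc(Nc3ccc(NC(=O)CCCCN=C=S)cc3)nc2n1C1CCCC1` is not yet measured. It differs from compound 3 by a group of 4 heavy atoms (2 carbon, 1 nitrogen, 1 sulfur; no ring) in place of a group of 3 heavy atoms (1 carbon, 1 nitrogen, 1 sulfur; no ring), on a saturated chain carbon, three bonds along the chain from a carbonyl carbon. This is the same kind of change as that from compound 1 to compound 2, though the place is not the same: there it sat six bonds along the chain from a sulfonamide nitrogen, here it sits three bonds along the chain from a carbonyl carbon. From compound 3 to compound 4 the step is expected to be a number 1 percentage points lower from compound 3 to compound 4 (within the scatter), since compound 3 already stands at 102% and the earlier step of no change at the digits printed from compound 1 to compound 2 (within the scatter). Compound 4 is therefore expected to give about 101% in this assay, most likely between 93% and 106%.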

Compound 4, a percentage reported as inhibition, at one concentration (the size of the read-out at that concentration, not a potency): 102%
For compound 4 the middle estimate is 1 percentage points below the measured one; measured number inside the range.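

In this assay the step on the core of compound 3 is no change at the digits printed from compound 3 to compound 4 (within the scatter), for the same change of a group of 3 heavy atoms to a group of 4 heavy atoms that was seen on the core of compound 1. Set side by side, the two steps do not differ, so in this small set the change carries from one core to the other with the same result: the same change on two cores in this assay, no change at the digits printed (within the scatter) from compound 1 to compound 2 and no change at the digits printed (within the scatter) from compound 3 to compound 4, 0 percentage points apart, within the scatter of two such steps This does not show that the change is without effect in general, since the read-out is a percentage at one concentration and not a potency, so any difference that would appear only at another concentration cannot be seen here, and the comparison rests on just two cores, with the change at a different place along the chain on each.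

The compounds shown leave open how the series would read with an amine or a carboxylic acid at the end of the chain in place of the carbon, nitrogen and sulfur group. They also leave open whether a longer chain on the core of compound 3 would keep to the same result, and whether the same agreement would hold for a potency read-out.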